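The source may report more compounds than this note shows. Statements on the series, on what has been measured and on what is new or still open speak of the compounds shown alone.

Working notes on the series. The three measured compounds share one core and differ only in the halogen pattern on the aromatic ring. Compound 3 `O=C(O)/C=C/C(=O)c1ccc(Cl)cc1` gives 25400 nM in a functional assay on HeLa cells (Homo sapiens) for inhibition, read by MTT assay, with a stated time of 72 h (a higher number here means a weaker inhibitor, a lower number a stronger inhibitor), and stands second highest of the three numbers. Compound 1 `O=C(O)/C=C/C(=O)c1ccc(Cl)cc1Cl` gives 62900 nM and compound 2 `O=C(O)/C=C/C(=O)c1ccc(Br)cc1` gives 18700 nM. The step of a 2.5-fold lower number from compound 1 to compound 3 (0.39 log units; beyond the scatter) is modest but beyond the scatter, whereas the step of a 1.4-fold higher number from compound 2 to compound 3 (0.13 log units; within the scatter) lies within the scatter, so the two values of compound 2 and compound 3 cannot be ordered.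

Compound 4 `O=C(O)/C=C/C(=O)c1ccc(Cl)c(Cl)c1` differs from compound 3 by chloro in place of hydrogen on an aromatic carbon. Within the data shown here, the only measured step in which a chloro group enters or leaves is the one from compound 1 to compound 3, where loss of a chloro gave a lower number; the chloro that enters in compound 4 sits at a different place, ortho to the existing chloro group, so that step bears on it only loosely. The swap from bromo to chloro in compound 2 and compound 3 changed little. A small rise in the number, of a size comparable to the step from compound 1 to compound 3 or smaller, is the expectation, with the direction not secure. This expectation corresponds to a 1.3-fold higher number from compound 3 to compound 4 (0.10 log units; within the scatter). For compound 4 the expected value in this assay is 32000 nM, with a range from 12000 nM to 80000 nM.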

Compound 4, half-maximal inhibitory concentration: 28300 nM
Compound 4: middle estimate off by 1.1-fold (0.05 log units), on the high side; the measured number falls inside the stated range.
By their numbers in this assay, from the lowest: compounds 2, 3 and 4 (each within the scatter of the next); then compound 1.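

In this assay, a chloro on an aromatic carbon ortho to a chloro group and meta to a group of 7 heavy atoms gives a step that stays within the scatter: a 1.1-fold higher number from compound 3 to compound 4 (0.05 log units; within the scatter). This is the only step shown in which a chloro enters at this position, and it shows that a second chloro on the ring does not by itself separate a compound from its monochloro partner: compound 4 gives 28300 nM, while compound 1, with its second chloro at another place, gives 62900 nM. No measured evidence bears on the reason for this result.

The compounds shown carry only halogens on the ring, so it remains open whether a group of another kind at this position, such as methoxy, an amine or a nitrile, would also leave the number unchanged within the scatter. Also open, from the compounds shown here alone, is whether bromo at this position would behave as chloro does here, and whether a larger group there would move the number at all.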